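One Further Side Chain on the Shared Core

The compounds below may be only part of what the source reports. "The series", "measured", "known", "first", "only" and "open" are said of these compounds alone.

Of the compounds shown here, three sharing a core have been measured in an ADME assay on HeLa cells (Homo sapiens) for cytotoxicity, read by MTT assay; a higher number here means a weaker inhibitor, a lower number a stronger inhibitor. Compound 1 `CCN(CC)C(=O)CCC(=O)Oc1ccc(C[C@H]2C(=O)OC[C@@H]2Cc2ccc(OC)c(OC)c2)cc1OC` gives 213000 nM and compound 3 `COc1ccc(C[C@H]2COC(=O)[C@@H]2Cc2ccc(OC(=O)CCC(=O)N3CCCC3)c(OC)c2)cc1OC` gives 201000 nM. Compound 2 `COc1ccc(C[C@H]2COC(=O)[C@@H]2Cc2ccc(OCc3cn(-c4ccc(Br)cc4)nn3)c(OC)c2)cc1OC`, which carries a different side chain, gives 128000 nM. The value of compound 3 lies within the scatter of both other values, so it cannot be separated from either.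

Compound 4 `CCN(CC)C(=O)COc1ccc(C[C@H]2C(=O)OC[C@@H]2Cc2ccc(OC)c(OC)c2)cc1OC` departs from compound 3 by a group of 8 heavy atoms (6 carbon, 1 nitrogen, 1 oxygen; no ring) in place of a group of 11 heavy atoms (8 carbon, 1 nitrogen, 2 oxygen; one five-membered non-aromatic ring with 1 hetero atom), on an oxygen on an aromatic ring. The entering group is (diethylcarbamoyl)methyl. Within the data shown here, one measured step bears on this change: a 1.1-fold lower number from compound 1 to compound 3 (0.03 log units; within the scatter), which lies within the scatter. Among the measured compounds shown here, that step covers only the exchange of pyrrolidin-1-yl and diethylamino, and no measured step isolates the remainder of the change. Given that small step and the value of compound 2 at 128000 nM, no shift beyond the scatter is expected in this assay. The expected change is a 1.1-fold lower number from compound 3 to compound 4 (0.05 log units; within the scatter). Compound 4 is estimated at 180000 nM, with an expected range from 100000 nM to 320000 nM.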

Compound 4, half-maximal inhibitory concentration: 188000 nM
For compound 4 the middle estimate is 1.0-fold (0.02 log units) below the measured one, within the range that was stated.
By their numbers in this assay, from the lowest: compounds 2, 4, 3 and 1 (each within the scatter of the next).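

On the oxygen on an aromatic ring, (diethylcarbamoyl)methyl cannot be told apart from the earlier groups of 11 heavy atoms in this assay with a 1.1-fold lower number from compound 3 to compound 4 (0.03 log units; within the scatter) and a 1.1-fold lower number from compound 1 to compound 4 (0.05 log units; within the scatter) on record, so the smaller chain without a ring gives no separation here. Diethylcarbamoyl in place of 1-(4-bromophenyl)-1H-1,2,3-triazol-4-yl on a saturated chain carbon bound to that oxygen gives a 1.5-fold higher number from compound 2 to compound 4 (0.17 log units; within the scatter) and likewise leaves the two compounds unseparated, so none of the side chains shown at this position stands apart from the others. Nothing measured on these compounds offers an explanation for this result.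

The compounds shown leave open whether any group on this oxygen can produce a step beyond the scatter in this assay and so define a real trend. A terminal carboxylic acid, a primary amine or a longer chain in that place would put this question to the test.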